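The compounds below may be only part of what the source reports. "The series", "measured", "known", "first", "only" and "open" are said of these compounds alone.

Series notes. For the measured compounds named here, compound 3 `C[C@H](NC(=O)c1c(-c2ccccc2)nnn1Cc1ccc(F)cc1)c1ccc(C(=O)O)cc1` stands at the lowest number of the three measured so far in a functional assay on CHO cells for antagonist activity at prostaglandin E2 receptor EP4 subtype (Homo sapiens), read by calcium flux, with a stated time of 15 min (a lower number here means a stronger inhibitor, a higher number a weaker inhibitor), where compound 3 gives 330 nM. Compound 2 `C[C@H](NC(=O)c1c(-c2ccccc2)nnn1Cc1ccccc1)c1ccc(C(=O)O)cc1` gives 647 nM in this assay, and the step of a 2.0-fold lower number from compound 2 to compound 3 (0.29 log units; within the scatter) is within the scatter, so compounds 2 and 3 cannot be separated. Compound 1 `C[C@H](NC(=O)c1c(C(F)(F)F)nnn1Cc1ccc(F)cc1)c1ccc(C(=O)O)cc1` gives 2320 nM in this assay, and the step of a 7.0-fold lower number from compound 1 to compound 3 (0.85 log units; beyond the scatter) is the one clear difference in the set.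

Compound 4 `C[C@H](NC(=O)c1c(-c2ccccc2)nnn1Cc1ccc(F)c(F)c1)c1ccc(C(=O)O)cc1` is not yet measured. It differs from compound 3 by fluoro in place of hydrogen on an aromatic carbon. Going by the values given here, the only measured step that bears on this change is the one from compound 2 to compound 3, where the same fluoro-for-hydrogen exchange on the benzyl ring gave a 2.0-fold lower number from compound 2 to compound 3 (0.29 log units; within the scatter), within the scatter. Among the compounds with values here, no measured step shows a second fluoro on that ring, and the step from compound 1 to compound 3 concerns a different position and a different group. On that basis a second fluoro is expected to leave the number in this assay close to that of compound 3, with the change a 1.2-fold lower number from compound 3 to compound 4 (0.07 log units; within the scatter) most likely within the scatter. Compound 4 is therefore estimated at 280 nM in this assay, with a range from 110 nM to 700 nM.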

Compound 4, half-maximal inhibitory concentration: 148 nM
Estimate against measurement, compound 4: 1.9-fold (0.28 log units) above; the range from low to high includes it.
By their numbers in this assay, from the lowest: compound 4; then compounds 3 and 2 (each within the scatter of the next); then compound 1.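

For the compounds shown here, on the benzyl ring, the change from 4-fluorobenzyl to 3,4-difluorobenzyl gives a 2.2-fold lower number from compound 3 to compound 4 (0.35 log units; beyond the scatter) and is the first fluoro-for-hydrogen exchange on this ring that can be read on its own, while the earlier exchange, a 2.0-fold lower number from compound 2 to compound 3 (0.29 log units; within the scatter) and no more, separated nothing. Read over the whole ring, 3,4-difluorophenyl in place of phenyl on the saturated chain carbon bound to an aromatic nitrogen gives a 4.4-fold lower number from compound 2 to compound 4 (0.64 log units; beyond the scatter) and shows that, with phenyl held on the core, the number in this assay responds to substitution on this ring. The data in hand offer no measured reason for either step.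

Open, going by these compounds, is whether the new fluoro itself matters at this place, or whether a chloro, methyl or methoxy group on the same aromatic carbon, ortho to a fluoro group, would give a similar step. Also open, on these data alone, is whether the 3,4-difluorobenzyl group gives a comparable step when trifluoromethyl stands on the core in place of phenyl, as it does in compound 1.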